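Two Compounds at the Floor and a Phenyl Analogue Untested

This account rests on a few compounds, and the source may have more. Where it says the series, first, only, none or still open, it means among the compounds named here.

Two compounds share one core, and neither moves in an assay on CHO cells for displacement of a labelled ligand from adenosine receptor A1 (Homo sapiens), read by scintillation counting, tested at 10 uM; on this read-out higher numbers stand for more inhibition at the one concentration tested (going by the name of the read-out) and lower numbers for less inhibition. Compound 1 `Cc1c(-c2ccccc2)sc(N)c1C(=O)c1ccc(Cl)cc1` gives 1% in this assay. Compound 2 `Cc1sc(N)c(C(=O)c2ccc(Cl)cc2)c1-c1ccccc1` gives 1% in this assay, level with compound 1 at the digits shown; the two numbers lie within the scatter of one another, so nothing separates them. No change of a single substitution between measured compounds has been followed so far.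

Compound 3 `Nc1sc(-c2ccccc2)c(-c2ccccc2)c1C(=O)c1ccc(Cl)cc1` has not yet been measured in this assay. It differs from compound 2 in one place: phenyl in place of methyl on an aromatic carbon. Within the data shown here, nothing measured so far points in any direction for this change, and compound 3 is expected to stay near the low level of compound 2 because compound 2 gives 1% there. The step from compound 2 to compound 3, a number 2 percentage points higher from compound 2 to compound 3 (within the scatter), is expected to fall within the scatter. Before the measurement is seen, compound 3 is estimated at 3%, with a range from -8% to 20%.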

Compound 3, a percentage reported as inhibition, at one concentration (the size of the read-out at that concentration, not a potency): 1%
The estimate for compound 3 lay 2 percentage points above the measured number; low and high end bracket the measured number.
By their numbers in this assay, from the lowest: compounds 1, 2 and 3 (each within the scatter of the next).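

In this assay, phenyl in place of methyl on an aromatic carbon next to the ring sulfur gives no change at the digits printed from compound 2 to compound 3 (within the scatter) and so adds a six-membered aromatic ring at this position without lifting the read-out from its low level. The same exchange of groups, read from the other compound that carries a methyl group, gives no change at the digits printed from compound 1 to compound 3 (within the scatter) and so provides a second step of this kind with the same outcome, which the earlier pair of compounds could not show because no single change linked them. No measurement on hand offers an explanation for this outcome.

All three compounds sit at the same low level, so these numbers cannot show whether the aromatic carbon matters at all, as any change that would reduce the read-out further would hardly be visible. Going by these compounds, it remains open whether an amine, a carboxylic acid or a longer chain on this carbon, or a different group in place of the amino group or the chlorine elsewhere on the shared core, would raise the number beyond the scatter.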